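Half-lives of three amino acid esters in one cell assay

The source may report more compounds than this note shows. Statements on the series, on what has been measured and on what is new or still open speak of the compounds shown alone.

- Compound 1 `N[C@@H](CCC(=O)OC[C@H]1O[C@@H](n2cc(F)c(=O)[nH]c2=O)C[C@@H]1OC(=O)CC[C@H](N)C(=O)O)C(=O)O` gives 0.238 h as its half-life
- Compound 2 `N[C@@H](CC(=O)OC[C@H]1O[C@@H](n2cc(F)c(=O)[nH]c2=O)C[C@@H]1O)C(=O)O` gives 0.223 h as its half-life
- Compound 3 `N[C@@H](CCC(=O)O[C@H]1C[C@H](n2cc(F)c(=O)[nH]c2=O)O[C@@H]1CO)C(=O)O` has not yet been measured

Going by the values given here, in an ADME assay on tissue (ZR-75-1 cells, Homo sapiens) for pharmacokinetics (on this read-out higher numbers stand for a longer-lived compound and lower numbers for a shorter-lived compound), only two numbers are available so far, and compound 1 stands within the usual scatter of compound 2. The step to compound 3 is a single structural change, with hydrogen in place of (3-amino-3-carboxypropyl)carbonyl on an oxygen on a saturated carbon. Among the compounds with values here, no measured step isolates this change. Compound 2, at 0.223 h in a different structure, still sits within the scatter of compound 1, so no step beyond the scatter is expected in this assay and no direction can be favoured. The expected 1.1-fold higher number from compound 1 to compound 3 (0.02 log units; within the scatter) therefore stays within the scatter. Compound 3 is estimated at 0.25 h in this assay with an expected range from 0.12 h to 0.5 h on this read-out.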

Compound 3, half-life: 0.132 h
Estimate against measurement, compound 3: 1.9-fold (0.28 log units) above, and the stated range covers the measured number.
By their numbers in this assay, from the lowest: compounds 3, 2 and 1 (each within the scatter of the next).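

In this assay the change now has a step of its own: with hydrogen in place of (3-amino-3-carboxypropyl)carbonyl on an oxygen on a saturated carbon, the read is a 1.8-fold lower number from compound 1 to compound 3 (0.26 log units; within the scatter) and stays within the scatter. The read-out therefore does not separate the compound carrying this group from the one with the free hydroxy, even though the change takes away 9 heavy atoms and a defined stereocentre. Nothing available explains this result.

On these data alone, whether an acetyl group, or a longer chain ending in an amine, on this same oxygen would give a step beyond the scatter remains open. Compound 2 differs from compound 1 and compound 3 in more than one place, so its steps to them cannot be read.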